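A few compounds are considered here, and "the series" means these few. Any claim that something is new, unique, unknown or untested is made for them only; others in the source may bear on it.

Compound 1 `Cc1nc(S(C)(=O)=O)ccc1Oc1ncnc(OC2CCN(C(=O)SC(C)C)CC2)c1F`: 6.8 nM
Compound 2 `Cc1nc(S(C)(=O)=O)ccc1Oc1ncnc(OC2CCN(C(=O)SC3(C)CC3)CC2)c1F`: 13.2 nM
Compound 3 `Cc1nc(S(C)(=O)=O)ccc1Oc1ncnc(OC2CCN(C(=O)C(C)(F)F)CC2)c1F`: 37 nM

In a functional assay on isolated protein for inhibition of Glucose-dependent insulinotropic receptor (Homo sapiens), read by HTRF and cAMP accumulation (a lower number here means that less compound is needed, a higher number that more compound is needed for the effect), compound 3 stands at the highest of the three numbers, with compound 2 nearest and compound 1 furthest away: the steps are a 2.8-fold higher number from compound 2 to compound 3 (0.45 log units; beyond the scatter) and a 5.4-fold higher number from compound 1 to compound 3 (0.74 log units; beyond the scatter), while a 1.9-fold higher number from compound 1 to compound 2 (0.29 log units; within the scatter). Compound 4 `Cc1nc(S(C)(=O)=O)ccc1Oc1ncnc(OC2CCN(C(=O)C3(C)CC3)CC2)c1F` differs from compound 3 by 1-methylcyclopropyl in place of 1,1-difluoroethyl on a carbonyl carbon. Within the data shown here, the step that bears most on this is a 2.8-fold higher number from compound 2 to compound 3 (0.45 log units; beyond the scatter), where the 1-methylcyclopropyl group was carried on a sulfur; here it sits directly on the carbonyl carbon, so no measured step matches the change exactly, and the isopropyl and 1-methylcyclopropyl pair showed little difference. Compound 4 is therefore expected to give a modestly lower number, a 2.1-fold lower number from compound 3 to compound 4 (0.31 log units; beyond the scatter), estimated at 18 nM with a range from 7 nM to 45 nM.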

Compound 4, half-maximal effective concentration: 761 nM
Compound 4: middle estimate off by 42-fold (1.63 log units), on the low side; the whole stated range lies below it.
By their numbers in this assay, from the lowest: compounds 1 and 2 (each within the scatter of the next); then compound 3; then compound 4.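

In this assay, on a carbonyl carbon whose other neighbour is an amide-type nitrogen in a ring, the two groups of 4 heavy atoms are far from interchangeable, with a 21-fold higher number from compound 3 to compound 4 (1.31 log units; beyond the scatter) on going to 1-methylcyclopropyl. That group read close to isopropyl when carried on sulfur, yet set directly on the carbonyl carbon it gives a 58-fold higher number from compound 2 to compound 4 (1.76 log units; beyond the scatter) and, against isopropylsulfanyl, a 110-fold higher number from compound 1 to compound 4 (2.05 log units; beyond the scatter) as well. No measurement shown accounts for these steps. As far as these compounds go, whether the ring or the fluorines decide the result remains open. A tert-butyl or 1,1-difluorocyclopropyl group on the same carbonyl carbon could separate the two.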